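The source may hold more compounds than are shown below. What is called first, only, known or untested is meant among the compounds shown, and "the series" means these compounds.

Measured compounds:
- compound 1, `CCCC(=O)c1ccc(OCCCCOc2cccc(C(=O)O)c2C)c(C)c1O`, gives 53% in an assay on HEK293 cells for positive allosteric modulation of metabotropic glutamate receptor 3 (Rattus norvegicus), read by thallium flux, with a stated time of 2.5 min; on this read-out higher numbers stand for larger maximal responses and lower numbers for smaller maximal responses
- compound 2, `CC(=O)c1ccc(OCCCCOc2ccc(F)c(C(=O)O)c2)c(C)c1O`, gives 16.8% in this assay

Among these two numbers compound 1 stands highest; the only other value, that of compound 2, lies lower by a gap beyond the usual scatter. Compound 2 also differs from compound 1 in more than one place, so its value alone says little about any single change.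

Compound 3, `CC(=O)c1ccc(OCCCCOc2cccc(C(=O)O)c2C)c(C)c1O`, has not yet been tested in this assay. It differs from compound 1 in one place: hydrogen in place of ethyl on a saturated chain carbon bound to a carbonyl carbon. Among the compounds with values here, no measured pair shows this change on the shared core, so its effect is uncertain. Within the data shown here, the account notes only that compound 2, which likewise carries an acetyl group, sits well below compound 1. On that basis a moderate fall from compound 1 to compound 3 is expected, a number 18 percentage points lower from compound 1 to compound 3 (beyond the scatter), with a wide range. The estimate for compound 3 in this assay is 35%, between 15% and 55%.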

Compound 3, largest response reached (reported as percent of maximum), in percent of the reference or control that the assay uses: 17.1%
Estimate against measurement, compound 3: 17.9 percentage points above, within the range that was stated.
By their numbers in this assay, from the lowest: compounds 2 and 3 (each within the scatter of the next); then compound 1.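

In this assay, within the data shown here, the change from propylcarbonyl to acetyl brings a number 35.9 percentage points lower from compound 1 to compound 3 (beyond the scatter) on the shared core, the first reading of this position with nothing else altered. The response therefore depends strongly on the ethyl at this saturated chain carbon bound to a carbonyl carbon, although the change removes only two carbon atoms and alters no hydrogen-bond donor, acceptor or net charge count. No measurement available here explains this fall.

From the compounds shown here alone, with only propylcarbonyl and acetyl compared at this position, the shape of the dependence on chain length remains open. A propanoyl group would show whether the response rises gradually or abruptly between these two, and a pentanoyl chain would show whether it keeps rising beyond propylcarbonyl.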